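Fluoro in Place of Methoxy: An Expectation for Compound 3

A few compounds are considered here, and "the series" means these few. Any claim that something is new, unique, unknown or untested is made for them only; others in the source may bear on it.

compound 1, `COc1ccc(/C=C/C[C@H]2C[C@@H]([C@@H](O)c3ccccc3)CO[C@@H]2c2ccccc2)cc1`: 8300 nM
compound 2, `COc1ccc([C@H](O)[C@H]2CO[C@H](c3ccc(OC)c(OC)c3)[C@@H](C/C=C/c3ccc(OC)c(OC)c3)C2)cc1`: 46000 nM

Among the measured compounds shown here, in a functional assay on HeLa cells (Homo sapiens) for cytotoxicity, read by WST assay, with a stated time of 48 h (on this read-out higher numbers stand for weaker inhibition and lower numbers for stronger inhibition), compound 1 gives the lower of the two numbers so far; compound 2 sits higher, beyond the usual scatter, but the two differ in more than one place, so only their values can be compared. Compound 3, `O[C@@H](c1ccccc1)[C@H]1CO[C@H](c2ccccc2)[C@@H](C/C=C/c2ccc(F)cc2)C1`, differs from compound 1 by fluoro in place of methoxy on an aromatic carbon. For the measured compounds named here, no measured pair shows this change, so in this assay little movement beyond the scatter is expected, in either direction. Compound 3 is therefore expected near 7000 nM, between 2500 nM and 20000 nM. The expected step is a 1.2-fold lower number from compound 1 to compound 3 (0.07 log units; within the scatter).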

Compound 3, half-maximal inhibitory concentration: 8340 nM
Beside the measured number, compound 3's estimate is 1.2-fold (0.08 log units) below it; the measured number falls inside the stated range.
By their numbers in this assay, from the lowest: compounds 1 and 3 (each within the scatter of the next); then compound 2.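

In this assay, among the compounds shown here, fluoro in place of methoxy on this aromatic carbon gives a 1.0-fold higher number from compound 1 to compound 3 (0.00 log units; within the scatter), the first step here that can be read at a single place. At this position, then, the two groups cannot be told apart on this read-out, and the methoxy is not required for the activity seen with compound 1. Nothing available explains this result. Going by these compounds, whether an amine or a carboxylic acid at the same position would also leave the number within the scatter remains open. Which of its several differences accounts for the number of compound 2 also remains open.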